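The source may hold more compounds than are shown below. What is called first, only, known or untested is meant among the compounds shown, and "the series" means these compounds.

Measured so far:
Compound 1 `CCS(=O)(=O)Nc1ccc(NC(=O)c2ccc(Cl)cc2)cc1OC` gives > 250000 nM in an ADME assay on HEK293 cells (Homo sapiens) for cytotoxicity, read by MTT assay, with a stated time of 48 h (a higher number here means a weaker inhibitor, a lower number a stronger inhibitor), which is a limit of the assay rather than a number.
Compound 2 `CCS(=O)(=O)Nc1ccc(NC(=O)c2ccc(Cl)c([N+](=O)[O-])c2)cc1OC` gives 63700 nM in this assay.
Compound 3 `COc1cc(NC(=O)c2ccc(Cl)c([N+](=O)[O-])c2)ccc1NS(=O)(=O)C(F)(F)F` gives > 250000 nM in this assay, again a limit and not a number.

Going by the values given here, compound 2 therefore holds the only number in this assay; the two other values shown sit at the limit of > 250000 nM in this assay, at which 2 of the 3 values shown sit. Compound 4 `CCS(=O)(=O)Nc1ccc(NC(=O)c2ccc(Cl)c([N+](=O)[O-])c2)cc1Cl` has not yet been measured in this assay. It differs from compound 2 by chloro in place of methoxy on an aromatic carbon.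

Among the compounds with values here, no measured step touches this place or this exchange. The two steps that exist both lie elsewhere: an at least 3.9-fold lower number from compound 1 to compound 2 (0.59 log units; beyond the scatter), and an at least 3.9-fold higher number from compound 2 to compound 3 (0.59 log units; beyond the scatter). Within the data shown here, each of them moved the number beyond the scatter, in opposite directions, but neither involves the methoxy group or a chloro group, so they give no direction for the step to compound 4. What they show is that single changes on this core have reached the limit of the assay twice out of three values.

With no direct guide, compound 4 is estimated at 70000 nM, in a range from 20000 nM to 250000 nM, and the assay may well report only a limit. That estimate means an expected step of a 1.1-fold higher number from compound 2 to compound 4 (0.04 log units; within the scatter), that is, no change beyond the scatter.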

Compound 4, half-maximal inhibitory concentration: 63800 nM
Estimate against measurement, compound 4: 1.1-fold (0.04 log units) above; the measured number falls inside the stated range.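

In this assay, chloro in place of methoxy is the first change shown on the aromatic carbon ortho to the (ethylsulfonyl)amino group, and it gives a 1.0-fold higher number from compound 2 to compound 4 (0.00 log units; within the scatter). The two earlier steps each moved the number beyond the scatter, whereas this exchange does not, so compound 2 and compound 4 cannot be told apart in this read-out. The methoxy group that leaves carries a hydrogen-bond acceptor and the chloro that enters carries none, which shows that, on this nitro-bearing core with the ethyl sulfonyl group, the number does not depend on keeping the methoxy group at this position.

Only this one exchange is shown here, so what an amine, a hydroxyl or a longer alkoxy chain such as ethoxy would do at this position stays open, as does whether chloro would behave the same way without the nitro group or with the trifluoromethyl on the sulfonyl sulfur. Compound 1 and compound 3 remain limits and not numbers, and how far either lies from compound 4 cannot be read: the limit of > 250000 nM in this assay, at which 2 of the 4 values shown sit.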